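From methyl to cyano on the aryl group

The source may report more compounds than this note shows. Statements on the series, on what has been measured and on what is new or still open speak of the compounds shown alone.

Measured in a functional assay on MKN-45 cells (Homo sapiens) for inhibition, read by CCK-8 assay, with a stated time of 24 h; on this read-out higher numbers stand for weaker inhibition and lower numbers for stronger inhibition:
- compound 1 `O=C1Nc2ccccc2/C1=C/c1ccc(-c2cn(-c3ccc(Cl)c(C(F)(F)F)c3)nn2)cc1`: 8890 nM
- compound 2 `Cc1ccccc1-n1cc(-c2ccc(C=C3C(=O)Nc4ccc(F)cc43)cc2)nn1`: 7210 nM
- compound 3 `Cc1cccc(-n2cc(-c3ccc(/C=C4\C(=O)Nc5ccc(F)cc54)cc3)nn2)c1`: 6810 nM

Compound 2 stands within the usual scatter of both other compounds, so the three values do not separate them. Compound 4 `N#Cc1ccccc1-n1cc(-c2ccc(C=C3C(=O)Nc4ccc(F)cc43)cc2)nn1` has not yet been measured in this assay. It differs from compound 2 by cyano in place of methyl on an aromatic carbon, ortho to a large group, so that 2-methylphenyl becomes 2-cyanophenyl: cyano in place of methyl on an aromatic carbon.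

Within the data shown here, no measured pair shows this exchange, so the data offer no direct guide to its effect. The only anchor is the narrow spread of the measured set, with compound 2 at 7210 nM and compound 3 at 6810 nM. No step beyond the scatter is therefore expected, in either direction. The expected change is a 1.2-fold lower number from compound 2 to compound 4 (0.08 log units; within the scatter). Compound 4 is estimated at 6000 nM, with an expected range from 2500 nM to 12000 nM.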

Compound 4, half-maximal inhibitory concentration: 15200 nM
Compound 4: middle estimate off by 2.5-fold (0.40 log units), on the low side; measured number above the stated range.
By their numbers in this assay, from the lowest: compounds 3, 2, 1 and 4 (each within the scatter of the next, the first and the last beyond it).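

In this assay, among these compounds, the exchange of methyl for cyano on an aromatic carbon, ortho to a large group, gives a 2.1-fold higher number from compound 2 to compound 4 (0.32 log units; beyond the scatter) and so provides the first step in this set between compounds that differ in one place. Though modest, it shows that this position is not indifferent to its substituent: here, 2-cyanophenyl gives weaker inhibition than 2-methylphenyl. No measurement on hand accounts for this step.

The compounds shown leave open whether this loss is particular to cyano or would also follow from a chlorine atom, a methoxy group or an amine at the same place. They also leave open whether cyano in place of the methyl group of compound 3 would produce a similar step.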